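Methyl on the 2-hydroxyethyl chain of compound 3

This account rests on a few compounds, and the source may have more. Where it says the series, first, only, none or still open, it means among the compounds named here.

Measured in a functional assay on OVCAR-8 cells (Homo sapiens) for antiproliferative activity; on this read-out lower numbers stand for stronger inhibition and higher numbers for weaker inhibition:
- compound 1 `Cn1ncc(Cl)c1-c1cc(C(=O)N[C@@H]2CN[C@H](CC(O)CO)C[C@H]2c2ccc(Cl)c(Cl)c2)oc1Cl`: 1610 nM
- compound 2 `CN(C)CC[C@@H]1C[C@@H](c2ccc(Cl)c(Cl)c2)[C@H](NC(=O)c2cc(-c3c(Cl)cnn3C)c(Cl)o2)CN1`: 1510 nM
- compound 3 `Cn1ncc(Cl)c1-c1cc(C(=O)N[C@@H]2CN[C@H](CCO)C[C@H]2c2ccc(Cl)c(Cl)c2)oc1Cl`: 610 nM

Compound 3 has the lowest number of the three, and its gaps to the other two lie beyond the scatter. The next compound, compound 4 `COCC[C@@H]1C[C@@H](c2ccc(Cl)c(Cl)c2)[C@H](NC(=O)c2cc(-c3c(Cl)cnn3C)c(Cl)o2)CN1`, turns its 2-hydroxyethyl into 2-methoxyethyl, with methyl in place of hydrogen on an oxygen on a saturated carbon. Within the data shown here, no measured step makes this exact change, so the evidence is indirect.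

Two measured steps reach the same chain: a 2.6-fold lower number from compound 1 to compound 3 (0.42 log units; beyond the scatter) and a 2.5-fold lower number from compound 2 to compound 3 (0.39 log units; beyond the scatter). Both are modest, and both end at compound 3. The third step, a 1.1-fold lower number from compound 1 to compound 2 (0.03 log units; within the scatter), shows two different chain ends with no separation beyond the scatter. Across these three compounds, chain changes have therefore moved the number by modest amounts at most. Among the measured compounds shown here, with only three compounds, this is a thin basis.

Adding a single carbon is expected to give a small move towards a higher number, most likely within the scatter. The expected step is a 1.3-fold higher number from compound 3 to compound 4 (0.12 log units; within the scatter). For compound 4 the estimated value is 800 nM, with an expected range of 350 nM to 1800 nM.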

Compound 4, half-maximal inhibitory concentration: 1060 nM
The estimate for compound 4 lay 1.3-fold (0.12 log units) below the measured number; the measured number falls inside the stated range.
By their numbers in this assay, from the lowest: compounds 3, 4, 2 and 1 (each within the scatter of the next, the first and the last beyond it).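

In this assay, among these compounds, methyl in place of hydrogen on the oxygen gives a 1.7-fold higher number from compound 3 to compound 4 (0.24 log units; within the scatter) and so provides the first direct reading at this oxygen, with 2-hydroxyethyl and 2-methoxyethyl not separated beyond the scatter. The other two new steps, a 1.4-fold lower number from compound 2 to compound 4 (0.15 log units; within the scatter) and a 1.5-fold lower number from compound 1 to compound 4 (0.18 log units; within the scatter) are also within the scatter, so compound 4 is separated from none of the other three chains, whereas compound 3 is separated beyond the scatter from compound 1 and compound 2. Nothing measured here accounts for these numbers.

A single methyl is the only group on this oxygen among the compounds shown, so it remains open whether an ethyl, a longer chain or a phenyl there would stay within the scatter of compound 3. As far as these compounds go, at the chain end, a primary amine or a carboxylic acid also remains open, as does whether either would give a separation from compound 3 beyond the scatter.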